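The compounds below may be only part of what the source reports. "The series", "measured", "known", "first", "only" and "open" are said of these compounds alone.

Among the measured compounds shown here, in an ADME assay on BHK-21 cells (Mesocricetus auratus) for cytotoxicity, read by MTT assay, with a stated time of 72 h (a higher number here means that more compound is tolerated, a lower number that less compound is tolerated), compound 2 `NS(=O)(=O)c1ccc(N2N=C(c3ccc(Oc4ccccc4)cc3)CC2c2cccc(F)c2)cc1` gives 10000 nM, the lower of the two numbers so far. Compound 1 `NS(=O)(=O)c1ccc(N2N=C(c3ccc(OCc4ccccc4)cc3)CC2c2ccccc2)cc1` gives 80000 nM, a higher number by more than the usual scatter. Compound 3 `NS(=O)(=O)c1ccc(N2N=C(c3ccc(OCc4ccccc4)cc3)CC2c2cccc(F)c2)cc1` differs from compound 2 in one place, with benzyl in place of phenyl on an oxygen on an aromatic ring. Compound 1 also carries benzyl on such an oxygen and gives 80000 nM, so a moderate upward change, beyond the scatter, is expected. The expected step is a 3.0-fold higher number from compound 2 to compound 3 (0.48 log units; beyond the scatter). For compound 3 the estimated value is 30000 nM, with an expected range of 10000 nM to 90000 nM.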

Compound 3, half-maximal cytotoxic concentration: 9000 nM
Compound 3: the middle estimate sits 3.3-fold (0.52 log units) above what was measured; the whole stated range lies above it.
By their numbers in this assay, from the lowest: compounds 3 and 2 (each within the scatter of the next); then compound 1.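

In this assay the change from phenyl to benzyl on the oxygen gives a 1.1-fold lower number from compound 2 to compound 3 (0.05 log units; within the scatter) and so does not separate the two compounds when the fluoro group is present. Fluoro in place of hydrogen on an aromatic carbon gives an 8.9-fold lower number from compound 1 to compound 3 (0.95 log units; beyond the scatter) and is the only one of these two steps beyond the scatter. Nothing available explains either result.

Going by these compounds, whether the phenyl to benzyl change would stay this small without the fluoro group remains open. So does the effect of a longer chain, such as phenethyl, or of an amine on the same oxygen-linked ring.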